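This account rests on a few compounds, and the source may have more. Where it says the series, first, only, none or still open, it means among the compounds named here.

Working notes on the series. In a functional assay on MCF7 cells (Homo sapiens) for cytotoxicity, read by MTT assay, with a stated time of 48 h (on this read-out higher numbers stand for weaker inhibition and lower numbers for stronger inhibition), compound 1 `O=C1/C(=C\c2ccc([N+](=O)[O-])cc2)S/C(=N/c2ccccc2)N1Cc1ccncc1` gives 13000 nM while compound 2 `CN(C)c1ccc(/C=C2/S/C(=N/c3ccccc3)N(Cc3ccncc3)C2=O)cc1` gives 76300 nM and compound 3 `COc1ccc(/C=C2/S/C(=N/c3ccccc3)N(Cc3ccncc3)C2=O)cc1OC` gives 80700 nM on the same read-out. Compound 3 shares the high end of this small set with compound 2, and compound 1 lies lower. Compound 4 `COc1ccc(OC)c(/C=C2/S/C(=N/c3ccccc3)N(Cc3ccncc3)C2=O)c1` carries 2,5-dimethoxyphenyl in place of 3,4-dimethoxyphenyl on a double-bonded chain carbon bound to a double-bonded ring carbon on a double-bonded chain carbon bound to a double-bonded ring carbon. The nearest measured evidence is a 1.1-fold higher number from compound 2 to compound 3 (0.02 log units; within the scatter) and the largest change at this carbon is a 6.2-fold higher number from compound 1 to compound 3 (0.79 log units; beyond the scatter) as well. Going by the values given here, no measured step compares two dimethoxyphenyl patterns, so no step beyond the scatter is expected in this assay here. The expected change is a 1.2-fold lower number from compound 3 to compound 4 (0.06 log units; within the scatter) for now. Compound 4 is estimated at 70000 nM (expected range 28000 nM to 150000 nM).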

Compound 4, half-maximal inhibitory concentration: 37000 nM
Compound 4: middle estimate off by 1.9-fold (0.28 log units), on the high side; low and high end bracket the measured number.
By their numbers in this assay, from the lowest: compound 1; then compound 4; then compounds 2 and 3 (each within the scatter of the next).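

In this assay, 2,5-dimethoxyphenyl in place of 3,4-dimethoxyphenyl gives a 2.2-fold lower number from compound 3 to compound 4 (0.34 log units; beyond the scatter) on the same atoms, so the dimethoxy pattern alone shifts the number beyond the scatter at this carbon. Compound 4 also separates from the 4-(dimethylamino)phenyl compound, with a 2.1-fold lower number from compound 2 to compound 4 (0.31 log units; beyond the scatter) as the step, yet 4-nitrophenyl keeps the lowest number of the set, with a 2.8-fold higher number from compound 1 to compound 4 (0.45 log units; beyond the scatter) as the step. No evidence available here bears on a cause for these steps.

As far as these compounds go, whether a single methoxy group, a hydroxyl group or a chlorine on this phenyl ring would lower the number further stays open.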